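The source may report more compounds than this note shows. Statements on the series, on what has been measured and on what is new or still open speak of the compounds shown alone.

Measured compounds in this series:
compound 1, `CC(C)c1ccccc1NC(=O)N[C@@H](C)c1ccccc1`: 93%
compound 2, `C[C@@H](NC(=O)Nc1cccc(C(F)(F)F)c1)c1ccccc1`: 70%
compound 3, `C[C@H](NC(=O)Nc1cccc(C(F)(F)F)c1)c1ccccc1`: 92%

In an ADME assay on the whole organism with Oryza sativa as the target, tested at 10 uM (on this read-out higher numbers stand for a weaker effect at the one concentration tested and lower numbers for a stronger effect), compound 2 stands lowest of the three numbers. The nearest value is that of compound 3, and the step of a number 22 percentage points higher from compound 2 to compound 3 (beyond the scatter) lies beyond the scatter; compound 1 sits somewhat further up again. Going by the values given here, the only step measured within one change is this one, and it rests on the fact that compounds 2 and 3 differ only in the configuration as drawn: the aromatic substituent is left untouched by it.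

Compound 4, `C[C@@H](NC(=O)Nc1cccc(Br)c1)c1ccccc1`, is reached from compound 2 by bromo in place of trifluoromethyl on an aromatic carbon. Among the compounds with values here, no measured pair changes this part of the molecule, so the stereo step a number 22 percentage points higher from compound 2 to compound 3 (beyond the scatter) does not bear on it directly; it only shows how far one change at a different site can move the number. Within the data shown here, with no direct precedent, the expectation is a step of about a number 8 percentage points higher from compound 2 to compound 4 (within the scatter), that is, a drift upward that may well stay within the scatter. Compound 4 is therefore estimated at 78%, with a range from 60% to 95%.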

Compound 4, a percentage reported as activity, at one concentration (the size of the read-out at that concentration, not a potency): 99%
Estimate against measurement, compound 4: 21 percentage points below; the measured number lies above the stated range.
By their numbers in this assay, from the lowest: compound 2; then compounds 3, 1 and 4 (each within the scatter of the next).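

In this assay, going by these compounds alone, the aromatic carbon meta to a large group proves sensitive, which the earlier compounds could not show: bromo in place of trifluoromethyl gives a number 29 percentage points higher from compound 2 to compound 4 (beyond the scatter). Within the data shown here, until now the only single change read lay at the stereocentre of the saturated chain, whereas this step leaves that centre as drawn and alters only the aromatic substituent, in which 4 heavy atoms leave and 1 heavy atom enters. Compound 2 therefore loses its low number through either of two separate single changes, one at the aromatic substituent and one purely stereochemical, and the latter is read from a number 22 percentage points higher from compound 2 to compound 3 (beyond the scatter): the fact that compounds 2 and 3 differ only in the configuration as drawn

As far as these compounds go, whether the low number of compound 2 is tied to trifluoromethyl as such remains open, since a single replacement by bromo cannot separate the identity of the group from its heavy-atom count, and a nitrile, a methoxy group or a carboxylic acid on the same aromatic carbon would be needed to tell these apart. Also open, from the compounds shown here alone, is whether the configuration and the aromatic substituent act independently, as the series shows each change only from compound 2.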